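Branch removal at the attachment carbon in a cyanoguanidine series

The source may hold more compounds than are shown below. What is called first, only, known or untested is meant among the compounds shown, and "the series" means these compounds.

Compound 3 `CCCC(C)(C)/N=C(\NC#N)Nc1cccnc1` stands lowest of the three numbers in a functional assay on the whole organism (blood, strain Wistar-Okamoto) with Rattus norvegicus as the target, with a stated time of 5 days (a lower number here means that less compound is needed, a higher number that more compound is needed for the effect), where compound 3 gives 1 mg/kg. Going by the values given here, compound 1 `CCCCC/N=C(\NC#N)Nc1cccnc1` gives 20 mg/kg and compound 2 `N#CN/C(=N\C1CCCC1)Nc1cccnc1` gives 20 mg/kg; the step of no change at the digits printed from compound 1 to compound 2 (within the scatter) is flat, while a 20-fold lower number from compound 1 to compound 3 (1.30 log units; beyond the scatter) and a 20-fold lower number from compound 2 to compound 3 (1.30 log units; beyond the scatter) are the only large steps seen. Compound 4 `N#CN/C(=N\CC1CCCO1)Nc1cccnc1` differs from compound 3 in one place: (oxolan-2-yl)methyl in place of 1,1-dimethylbutyl on a double-bonded nitrogen. The two large steps bear on this change in the reverse sense, since pentyl and cyclopentyl, both lacking the two methyls, sit at the higher number; the expected outcome is therefore a rise of about a 15-fold higher number from compound 3 to compound 4 (1.18 log units; beyond the scatter) for compound 4. Compound 4 is estimated at 15 mg/kg, with a range of 4 mg/kg to 50 mg/kg.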

Compound 4, minimum effective dose: 50 mg/kg
Compound 4: the middle estimate sits 3.3-fold (0.52 log units) below what was measured; low and high end bracket the measured number.
By their numbers in this assay, from the lowest: compound 3; then compounds 1 and 2 (each within the scatter of the next); then compound 4.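

In this assay, swapping 1,1-dimethylbutyl for (oxolan-2-yl)methyl, both of 6 heavy atoms, gives a 50-fold higher number from compound 3 to compound 4 (1.70 log units; beyond the scatter) and shows that the heavy-atom count alone does not set the number at this position. The group also falls short of the two groups lacking the two methyls, with a 2.5-fold higher number from compound 2 to compound 4 (0.40 log units; beyond the scatter) and a 2.5-fold higher number from compound 1 to compound 4 (0.40 log units; beyond the scatter) as modest steps beyond the scatter. No measurement at hand accounts for these steps. On these data alone, it remains open whether a 1-methylbutyl group with a single methyl, or a tert-butyl group, keeps the low number of compound 3.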